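Adding chloro to compound 1

The source may hold more compounds than are shown below. What is called first, only, known or untested is meant among the compounds shown, and "the series" means these compounds.

Of the compounds shown here, three have numbers so far in a physicochemical assay for solubility, in phosphate buffer, measured as kinetic solubility, with a stated time of 24 h, at pH 6.5; on this read-out higher numbers stand for higher solubility and lower numbers for lower solubility. Compound 1 `CC(C)Oc1cc(Oc2ccc(S(C)(=O)=O)cc2)cc(-c2nccc(=O)[nH]2)c1` gives 25000 nM, the lowest of the three and beyond the scatter from each of the others. Compound 2 `CC(C)Oc1cc(Oc2cnc(C(=O)N(C)C)nc2)cc(-c2nccc(=O)[nH]2)c1` gives 332000 nM. Compound 3 `CCS(=O)(=O)c1ccc(Oc2cc(O[C@@H](C)CO)cc(-c3nccc(=O)[nH]3)c2)cc1` gives 390000 nM. These last two values lie within the scatter of each other. Within the data shown here, no two of the measured compounds differ in only one place, so the series offers no direct measure of any single change, and nothing measured so far speaks for the change considered here.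

Compound 4 `CC(C)Oc1cc(Oc2ccc(S(C)(=O)=O)cc2)cc(-c2ncc(Cl)c(=O)[nH]2)c1` keeps the core of compound 1 and differs from it in one place: chloro in place of hydrogen on an aromatic carbon. This is chloro in place of hydrogen on an aromatic carbon, on the six-membered aromatic ring with 2 nitrogen.

Among the measured compounds shown here, with no measured step to lean on, the expectation in this assay is a modest fall, of about the size of the scatter, starting from compound 1 at 25000 nM. A result with no change beyond the scatter would be no surprise. The expected step is a 1.9-fold lower number from compound 1 to compound 4 (0.28 log units; within the scatter). For compound 4 the estimate is 13000 nM, with an expected range of 4000 nM to 30000 nM.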

Compound 4, solubility: 24000 nM
Beside the measured number, compound 4's estimate is 1.8-fold (0.27 log units) below it; the range from low to high includes it.
By their numbers in this assay, from the lowest: compounds 4 and 1 (each within the scatter of the next); then compounds 2 and 3 (each within the scatter of the next).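

In this assay, among these compounds, chloro in place of hydrogen on an aromatic carbon of the six-membered aromatic ring with 2 nitrogen gives a 1.0-fold lower number from compound 1 to compound 4 (0.02 log units; within the scatter), the first step that isolates a single change. On the background of compound 1, this position, two atoms from the ring nitrogen and para to a large group, therefore takes one chlorine atom with no shift that can be told from the scatter. The earlier compounds shown here could not show this, since no two of them differed in only one place.

Going by these compounds, whether the same position stays as quiet with a methyl, a methoxy, an amine or a carboxylic acid in place of chloro remains open, as a single substituent gives no trend across groups. Also open, on these data alone, is whether chloro at this position gives a similar step when the other parts of the molecule are those of compound 2 or compound 3, which carry different groups on the shared core. No supporting measurement is available that bears on the reason for this result.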